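Swapping isopropoxy for dimethylamino on two related cores

The source may report more compounds than this note shows. Statements on the series, on what has been measured and on what is new or still open speak of the compounds shown alone.

Measured so far:
compound 1 `CN(C)c1ccc(-c2ccc(NC(=O)c3ccccc3)nc2)cc1` gives 14%
compound 2 `CC(C)Oc1ccc(-c2ccc(NC(=O)c3ccccc3)nc2)cc1` gives 38%
compound 3 `CC(C)Oc1ccc(C(=O)Nc2ccc(-c3ccccc3)cn2)cc1` gives 12%

All three were tested in an assay on isolated protein (Aquatica lateralis) for inhibition of Luciferin 4-monooxygenase (Luciola lateralis), read by a luciferase reporter, tested at 10 uM; on this read-out higher numbers stand for more inhibition at the one concentration tested (going by the name of the read-out) and lower numbers for less inhibition. Compound 2 carries an isopropoxy group and stands highest of the three. Replacing it gives compound 1, and that change, (dimethylamino in place of isopropoxy on an aromatic carbon), brought a number 24 percentage points lower from compound 2 to compound 1 (beyond the scatter). Compound 3 shares its atoms with compound 2 but joins them differently; the difference between the two cores is not broken down here. Compound 3 and compound 1 lie within the usual scatter of each other.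

Compound 4 `CN(C)c1ccc(C(=O)Nc2ccc(-c3ccccc3)cn2)cc1` has not yet been measured. For the measured compounds named here, it differs from compound 3 by dimethylamino in place of isopropoxy on an aromatic carbon, the same change as the one from compound 2 to compound 1, made at the same kind of place. Since compound 3 already starts from 12%, there is little room for a drop of the earlier size. The expected step is a number 7 percentage points lower from compound 3 to compound 4 (within the scatter), smaller than a number 24 percentage points lower from compound 2 to compound 1 (beyond the scatter) because compound 3 sits at 12%. Compound 4 is therefore estimated at 5%, with a likely range from -8% to 20%.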

Compound 4, a percentage reported as inhibition, at one concentration (the size of the read-out at that concentration, not a potency): 35%
For compound 4 the middle estimate is 30 percentage points below the measured one; the whole stated range lies below it.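

In this assay, putting dimethylamino in place of isopropoxy on the core of compound 3 brought a number 23 percentage points higher from compound 3 to compound 4 (beyond the scatter). Set beside the earlier step, this shows that the same swap, made at the same kind of place, moved the number in opposite directions on the two cores, so a step seen on one core could not be carried over to the other here: the same change on two cores in this assay, a number 24 percentage points lower (beyond the scatter) from compound 2 to compound 1 and a number 23 percentage points higher (beyond the scatter) from compound 3 to compound 4, 47 percentage points apart, beyond the scatter of two such steps

What this does not show is why the two cores part ways, and two pairs of compounds are too few to set a rule for any core beyond these two.

The compounds shown leave open how other groups at this place, such as a methoxy group, a primary amine or a carboxylic acid, would behave on each core, and whether any of them would also change direction from one core to the other. They also leave open whether these differences at one concentration would hold across a range of concentrations.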